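This account rests on a few compounds, and the source may have more. Where it says the series, first, only, none or still open, it means among the compounds named here.

Measured compounds:
- compound 1, `C[C@@H](NCc1ccc(Cl)cc1)[C@H]1CC[C@@H](c2ccnc3ccc(F)cc32)CC1`: 745 nM
- compound 2, `C[C@@H](c1nc2ccc(Cl)cc2[nH]1)[C@H]1CC[C@@H](c2ccnc3ccc(F)cc32)CC1`: 4 nM
- compound 3, `C[C@@H](CNC(=O)c1ccc(Cl)cc1)[C@H]1CC[C@@H](c2ccnc3ccc(F)cc32)CC1`: 261 nM

The three compounds share one core and differ in the group carried on the side chain. In an assay on tissue (HeLa cells) for inhibition of Indoleamine 2,3-dioxygenase 1 (Homo sapiens), with stated times of 2 h and 18 h (on this read-out lower numbers stand for stronger inhibition and higher numbers for weaker inhibition), compound 1 gives 745 nM, the highest of the three numbers. Compound 3, with a (4-chlorophenyl)carbonyl amide on a longer chain, gives 261 nM, a lower number than compound 1 by a margin beyond the scatter. Compound 2, whose side chain carries a benzimidazole, gives 4 nM, by far the lowest number here.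

Compound 4, `C[C@@H](NC(=O)c1ccccc1Cl)[C@H]1CC[C@@H](c2ccnc3ccc(F)cc32)CC1`, has not yet been measured. It differs from compound 1 by (2-chlorophenyl)carbonyl in place of 4-chlorobenzyl on an amine nitrogen. Going by the values given here, no measured pair isolates exactly this change. Because compound 3 gives 261 nM with a related carbonyl in place of the benzyl of compound 1, the step from compound 1 to compound 4 is expected to be downward, of moderate size, a 2.5-fold lower number from compound 1 to compound 4 (0.40 log units; beyond the scatter). Compound 4 is therefore estimated at 300 nM, with a range from 60 nM to 1500 nM.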

Compound 4, half-maximal inhibitory concentration: 12 nM
The estimate for compound 4 lay 25-fold (1.40 log units) above the measured number; measured number below the stated range.
By their numbers in this assay, from the lowest: compound 2; then compound 4; then compound 3; then compound 1.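

In this assay, the exchange of 4-chlorobenzyl for (2-chlorophenyl)carbonyl on the amine nitrogen gives a 62-fold lower number from compound 1 to compound 4 (1.79 log units; beyond the scatter), a large step. Going by these compounds alone, this is the first change in a single place, and it shows that the group on this nitrogen can move the read-out strongly even though the chain and the shared core stay the same. The entering group adds a carbonyl with its hydrogen-bond acceptor and also carries its chlorine at a different ring position, and nothing available accounts for the size of the step.

The compounds shown leave open whether the carbonyl or the place of the chlorine carries the step. A 2-chlorobenzyl group or an unsubstituted benzoyl group on this nitrogen would separate the two.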